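The source may report more compounds than this note shows. Statements on the series, on what has been measured and on what is new or still open speak of the compounds shown alone.

Four compounds of one series are considered here, all built around a thioether linking a substituted benzyl group to a heteroaromatic core, and all tested in a functional assay on BGC-823 cells (Homo sapiens) for antiproliferative activity, read by MTT assay, with a stated time of 48 h; a higher number here means a weaker inhibitor, a lower number a stronger inhibitor. Compound 1 `Clc1ccccc1CSc1nnc(-c2cnccn2)o1` gives 27700 nM in this assay. Compound 2 `Brc1ccccc1CSc1nnc(-c2cnccn2)o1` differs from compound 1 only in the halogen on the benzyl ring, a change summarised as bromo in place of chloro on an aromatic carbon. In this assay compound 2 gives 17600 nM. This change made a step of a 1.6-fold lower number from compound 1 to compound 2 (0.20 log units; within the scatter) in this assay. Compound 3 `Clc1ccccc1CSc1nnc(-c2cnccn2)n1-c1ccccc1` carries a different core, and the difference between the core of compound 3 and the core of compound 1 is not broken down here. In this assay compound 3 gives 34700 nM, which sits within the scatter of compound 1 and of compound 2.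

Compound 4 `Brc1ccccc1CSc1nnc(-c2cnccn2)n1-c1ccccc1` has not yet been measured. It differs from compound 3 by bromo in place of chloro on an aromatic carbon, the same change that separates compound 2 from compound 1, made at the same place. In this assay, among the compounds with values here, the earlier step was a 1.6-fold lower number from compound 1 to compound 2 (0.20 log units; within the scatter), and compound 4 is expected to move in a similar way from compound 3, that is by about a 1.6-fold lower number from compound 3 to compound 4 (0.20 log units; within the scatter), resting on the one earlier instance of this change and on the values of compound 1 and compound 2. Compound 4 is therefore estimated to give about 22000 nM in this assay, most likely between 12000 nM and 42000 nM.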

Compound 4, half-maximal inhibitory concentration: 36200 nM
Beside the measured number, compound 4's estimate is 1.6-fold (0.22 log units) below it; low and high end bracket the measured number.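

In this assay, the step on the core of compound 3 is a 1.0-fold higher number from compound 3 to compound 4 (0.02 log units; within the scatter), so bromo in place of chloro leaves no readable mark on this core, just as it left none on the core of compound 1. Set side by side, the two steps do not differ by more than repeated measurement would allow: the same change on two cores in this assay, a 1.6-fold lower number (0.20 log units; within the scatter) from compound 1 to compound 2 and a 1.0-fold higher number (0.02 log units; within the scatter) from compound 3 to compound 4, 1.6-fold (0.22 log units) apart, within the scatter of two such steps. This shows that, within these two pairs, the change behaves alike on both cores, but not that it has a real effect that carries from one core to the other, as neither step lies beyond the scatter and two pairs say nothing about any further core in the series.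

The compounds shown hold only chloro and bromo on the benzyl ring, which leaves open whether a fluoro, a methoxy, a nitrile or an amine at that place would give a step beyond the scatter, and whether such a step would then hold on both cores. They also leave open what a methyl or a longer chain would do in place of the phenyl group on the core of compound 3.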